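The source may report more compounds than this note shows. Statements on the series, on what has been measured and on what is new or still open speak of the compounds shown alone.

Series notes. Among the measured compounds shown here, the shared core of compound 1 `COc1ccc(OC)c(Sc2ccc3nnc(-c4cccnc4)n3n2)c1` carries a pyridin-3-yl group; in an assay on isolated protein for inhibition of Leucine-rich repeat serine/threonine-protein kinase 2 (Homo sapiens), in the presence of a further agent that is not named here (a lower number here means a stronger inhibitor, a higher number a weaker inhibitor), compound 1 gives 242 nM, the second highest of the three numbers so far. Compound 2 `COc1ccc(OC)c(Sc2ccc3nnc(-c4cnccn4)n3n2)c1` carries pyrazin-2-yl in its place and in this assay compound 2 gives 880 nM; the step of a 3.6-fold higher number from compound 1 to compound 2 (0.56 log units; beyond the scatter) lies beyond the scatter. Compound 3 `COc1ccc(OC)c(Sc2ccc3nnc(-c4ccsn4)n3n2)c1` carries 1,2-thiazol-3-yl and in this assay compound 3 gives 91 nM; the step of a 2.7-fold lower number from compound 1 to compound 3 (0.42 log units; beyond the scatter) is also beyond the scatter, as is a 9.7-fold lower number from compound 2 to compound 3 (0.99 log units; beyond the scatter). Compound 4 `COc1ccc(OC)c(Sc2ccc3nnc(-c4ccn(C)n4)n3n2)c1` is not yet measured. It differs from compound 1 in one place: 1-methyl-1H-pyrazol-3-yl in place of pyridin-3-yl on an aromatic carbon. The most relevant comparison is a 2.7-fold lower number from compound 1 to compound 3 (0.42 log units; beyond the scatter), where a five-membered aromatic ring with 2 hetero atoms likewise replaced pyridin-3-yl and the number fell; the step of a 3.6-fold higher number from compound 1 to compound 2 (0.56 log units; beyond the scatter) went the other way. A modest lowering is therefore expected for compound 4, a 1.6-fold lower number from compound 1 to compound 4 (0.21 log units; within the scatter), though with a single comparable step the range is wide. Compound 4 is estimated at 150 nM in this assay, expected to fall between 50 nM and 450 nM.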

Compound 4, half-maximal inhibitory concentration: 224 nM
For compound 4 the middle estimate is 1.5-fold (0.17 log units) below the measured one; measured number inside the range.
By their numbers in this assay, from the lowest: compound 3; then compounds 4 and 1 (each within the scatter of the next); then compound 2.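

The step of a 1.1-fold lower number from compound 1 to compound 4 (0.03 log units; within the scatter) shows that in this assay a five-membered aromatic ring with 2 hetero atoms does not by itself lower the number at this position, and 1-methyl-1H-pyrazol-3-yl cannot be told apart from pyridin-3-yl. The step of a 2.5-fold higher number from compound 3 to compound 4 (0.39 log units; beyond the scatter) separates two such rings, so the lower number of compound 3 belongs to 1,2-thiazol-3-yl rather than to ring size or hetero atom count alone. Among the compounds shown here, with a 3.9-fold lower number from compound 2 to compound 4 (0.59 log units; beyond the scatter) as the third step, pyrazin-2-yl remains the only group here whose number is higher than all the others beyond the scatter.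

No data shown here explain these differences.
From the compounds shown here alone, it remains open whether a non-aromatic substituent on this carbon, such as an amine or a carboxylic acid, would keep the number near these values.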